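Three Methoxy Groups on the Amide Aryl of Compound 2

The source may report more compounds than this note shows. Statements on the series, on what has been measured and on what is new or still open speak of the compounds shown alone.

Within the data shown here, compound 2 `O=C(Nc1ccccc1)c1csc(-c2cn(Cc3ccc(Cl)cc3)c3ccccc23)n1` is the only member of this small set that gives an actual number in a functional assay on LNCaP cells (Homo sapiens) for cytotoxicity, read by MTT assay, with a stated time of 48 h, in the presence of a further agent that is not named here; a higher number here means a weaker inhibitor, a lower number a stronger inhibitor: compound 2 gives 68900 nM. Compound 1 `COc1ccc(NC(=O)c2csc(-c3cn(Cc4ccc(Cl)cc4)c4ccccc34)n2)cc1` carries a methoxy on the aromatic carbon of that same aryl ring. In this assay compound 1 reaches only the limit of the assay, > 100000 nM. Compound 3 `O=C(Nc1ccccc1)c1csc(-c2c[nH]c3ccccc23)n1` lacks the 4-chlorobenzyl on the aromatic nitrogen. In this assay compound 3 likewise reaches only the limit, > 100000 nM. Both changes away from compound 2 are therefore recorded as steps that end at the limit: an at least 1.4-fold lower number from compound 1 to compound 2 (0.16 log units; that floor lies within the scatter) and an at least 1.4-fold higher number from compound 2 to compound 3 (0.16 log units; that floor lies within the scatter) describe floors rather than exact sizes, and the evidence for them is the limit of > 100000 nM in this assay, at which 2 of the 3 values shown sit.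

Compound 4 `COc1cc(NC(=O)c2csc(-c3cn(Cc4ccc(Cl)cc4)c4ccccc34)n2)cc(OC)c1OC` differs from compound 2 by 3,4,5-trimethoxyphenyl in place of phenyl on an amide-type nitrogen. Among the measured compounds shown here, the one step that bears on this change is the methoxy step, which removed the number altogether when a single methoxy was present. Adding three methoxy groups is expected to go in the same direction, towards a weaker inhibitor, so the step from compound 2 to compound 4 is expected to be a 2.2-fold higher number from compound 2 to compound 4 (0.34 log units; beyond the scatter). Compound 4 is estimated at 150000 nM, with a range from 50000 nM to 500000 nM.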

Compound 4, half-maximal inhibitory concentration: > 100000 nM
Compound 4 ended at the assay's limit (the forecaster's own chance of this, stated with the estimate: 70%); the middle value does not contradict the limit.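

Compound 4 shows that the heavier 3,4,5-trimethoxyphenyl on the amide-type nitrogen also gives no number in this assay, and the change is recorded only as an at least 1.4-fold higher number from compound 2 to compound 4 (0.16 log units; that floor lies within the scatter). Both methoxy-bearing aryl groups shown at this position, the single methoxy of compound 1 and the three methoxy groups of compound 4, now end at the limit, while the plain phenyl of compound 2 alone gives a number; the step between compound 1 and compound 4 cannot be read, as both values are limits. This makes the trend look more consistent without making it larger, and a real loss from adding methoxy groups remains unproven, with everything resting on a single ceiling: the limit of > 100000 nM in this assay, at which 3 of the 4 values shown sit.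

From the compounds shown here alone, how far compound 1 and compound 4 actually lie past the limit stays open, and so does whether the number of methoxy groups matters at all. Also open, going by these compounds, is whether a fluorine, a hydroxy or a dimethylamino group on the phenyl ring of compound 2 would give a measurable number, and on which side of the value of compound 2 it would fall.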